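Swapping a fused ring group at one position

The source may report more compounds than this note shows. Statements on the series, on what has been measured and on what is new or still open speak of the compounds shown alone.

compound 1 `CC/C(=C(/c1ccc(/C=C/C(=O)O)cc1)c1ccc2[nH]ncc2c1)c1ccccc1`: 7.2 nM
compound 2 `CC/C(=C(/c1ccc(/C=C/C(=O)O)cc1)c1ccn2ccnc2c1)c1ccccc1`: > 500 nM (a limit of the assay)

Both values come from a functional assay on MCF7 cells (Homo sapiens) for antiproliferative activity, read by CellTiter-Glo, with a stated time of 5 days; on this read-out higher numbers stand for weaker inhibition and lower numbers for stronger inhibition. Compound 2 stands at the limit of > 500 nM in this assay, at which 1 of the 2 values shown sits, so its entry is a limit and not a number.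

Compound 3 `CC/C(=C(/c1ccc(/C=C/C(=O)O)cc1)c1ccc2ncsc2c1)c1ccccc1` differs from compound 2 at a single place: a group of 9 heavy atoms (7 carbon, 1 nitrogen, 1 sulfur; one five-membered aromatic ring with 2 hetero atoms, one six-membered aromatic ring of carbon only) in place of a group of 9 heavy atoms (7 carbon, 2 nitrogen; one five-membered aromatic ring with 2 hetero atoms, one six-membered aromatic ring with 1 hetero atom), on a double-bonded chain carbon bound to an aromatic carbon and a double-bonded chain carbon. The 1,3-benzothiazol-6-yl group enters on a double-bonded chain carbon bound to an aromatic carbon and a double-bonded chain carbon.

Going by the values given here, only one measured step bears on this change. In it, an at least 69-fold higher number from compound 1 to compound 2 (1.84 log units; beyond the scatter), and the group at that same place gained a hetero atom in its six-membered aromatic ring. Compound 3 again has a six-membered aromatic ring of carbon only, as compound 1 does, although its five-membered ring differs. Given that large step, a clear move toward stronger inhibition is expected, but probably not a full return to the value of compound 1. The expected change is an at least 8.3-fold lower number from compound 2 to compound 3 (0.92 log units; beyond the scatter), and this estimate is uncertain. For compound 3 the estimated value is 60 nM, with an expected range from 10 nM to 350 nM.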

Compound 3, half-maximal inhibitory concentration: > 500 nM
Compound 3: a limit, no number (the forecaster's own chance of this, stated with the estimate: 15%); middle value at least 8.3-fold (0.92 log units) away from the limit.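

In this assay, a six-membered aromatic ring of carbon only proves not to be enough at this place on the double-bonded chain carbon: 1,3-benzothiazol-6-yl in place of 1H-indazol-5-yl gives an at least 69-fold higher number from compound 1 to compound 3 (1.84 log units; beyond the scatter). The earlier step could be read as a loss tied to the hetero atom in the six-membered ring of compound 2, but compound 3 has no such atom and still shows no measurable value, so that hetero atom cannot be the whole story, and the five-membered ring, which here holds sulfur, now also comes into question. Compound 3, at > 500 nM, stands at a limit of the assay and not at a number, so the step between compound 2 and compound 3 cannot be read and the two groups cannot be ranked: the limit of > 500 nM in this assay, at which 2 of the 3 values shown sit.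

From the compounds shown here alone, how far the activity of compound 2 and compound 3 lies beyond the limit stays unknown. Going by these compounds, it also stays open whether a closely related fused group, such as 1H-indol-5-yl or 1H-benzimidazol-5-yl, would keep the value of compound 1 at this place.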